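This account rests on a few compounds, and the source may have more. Where it says the series, first, only, none or still open, it means among the compounds named here.

Measured compounds:
compound 1 `CCCCCCCCCCCOc1ccccc1CCC(=O)OC[C@H]1OCC=C[C@@H]1OP(=O)(O)OC[C@H](N)C(=O)O` — < 3%
compound 2 `N[C@@H](COP(=O)(O)O[C@@H]1C=CCO[C@@H]1COC(=O)CCc1ccccc1OCc1cccc(Oc2ccccc2)c1)C(=O)O` — 12.4%
compound 3 `CCCCCCCCCCCOc1ccccc1CCC(=O)OCc1ccc(OP(=O)(O)OC[C@H](N)C(=O)O)cc1` — "not active" (no number reported)

In an assay on HEK293-A cells for agonist activity at probable G-protein coupled receptor 34 (Mus musculus), with a stated time of 1.5 h (on this read-out lower numbers stand for smaller maximal responses and higher numbers for larger maximal responses), compound 1 gives < 3%, which is a limit of the assay and not a number. That reading sits at the limit of < 3% in this assay, at which 1 of the 3 values shown sits. Compound 2 gives 12.4% in this assay. Compound 3 is recorded in this assay as "not active" (no number reported). Among the compounds with values here, no step between these measured compounds is tracked, so of compound 1 and compound 2 only their two values can be stated side by side.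

Compound 4 `CCCCCCCCCCCOc1ccccc1CCC(=O)OC[C@H]1OCC=C[C@H]1OP(=O)(O)OC[C@H](N)C(=O)O` differs from compound 1 in this way: the two compounds have the same atoms and bonds; at least one stereo element is drawn with a configuration in one of them and without one in the other: 1 of 4 stereo elements differ; a stereocentre at a saturated ring carbon is drawn S in compound 1 and R in compound 4. Within the data shown here, no measured pair shows what such an inversion does in this assay, so the size of the step is not known from the data. Compound 1 stands at the limit, and the expectation for compound 4 starts from there. Compound 4 is expected to give about 8%, within 0% to 35%. The expected step of a number at least 5 percentage points higher from compound 1 to compound 4 (that floor lies within the scatter) is therefore small, not clearly beyond the usual scatter, with a fair chance that only a limit is again reported.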

Compound 4, largest response reached (Emax), in percent of the reference or control that the assay uses: 5%
Compound 4: the middle estimate sits 3 percentage points above what was measured, and the stated range covers the measured number.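

In this assay, within the data shown here, inverting the stereocentre at a saturated ring carbon, drawn S in compound 1 and R in compound 4, gives the first step that can be read at this position: a number at least 2 percentage points higher from compound 1 to compound 4 (that floor lies within the scatter). Compound 1 stands at < 3%, which is a limit of the assay and not a number. The inversion therefore does not separate the two configurations clearly from the scatter, and the step rests on a bound rather than on two numbers: the limit of < 3% in this assay, at which 1 of the 4 values shown sits.

The compounds shown leave open whether this inversion would read the same way with the side chain of compound 2 in place of the one shared by compound 1 and compound 4. They also leave open how an amide in place of the ester would read in this assay with either configuration at this carbon.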